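A few compounds are considered here, and "the series" means these few. Any claim that something is new, unique, unknown or untested is made for them only; others in the source may bear on it.

Working notes on the series. In a functional assay on RAW264.7 cells (Mus musculus) for inhibition, read by Griess assay, with stated times of 1 h and 24 h (on this read-out higher numbers stand for weaker inhibition and lower numbers for stronger inhibition), compound 3 (`COc1ccccc1C1CC(=O)c2ccccc2O1`) gives 47300 nM, compound 1 (`CC(C)c1ccc(COc2ccccc2C2CC(=O)c3ccccc3O2)cc1`) gives 27100 nM, and compound 2 (`C=CCOc1ccccc1C1CC(=O)c2ccccc2O1`) gives 37800 nM. All three values lie within the scatter of each other, so compound 3 cannot be separated from the other two on these numbers.

The next compound, compound 4 (`O=C1CC(c2ccccc2OCc2cccc(F)c2)Oc2ccccc21`), has 3-fluorophenyl in place of hydrogen on a saturated chain carbon bound to an oxygen on an aromatic ring.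

The closest measured change at this place is a 1.7-fold higher number from compound 1 to compound 3 (0.24 log units; within the scatter), where hydrogen replaces 4-isopropylphenyl. The vinyl compound gives two further steps, a 1.4-fold higher number from compound 1 to compound 2 (0.14 log units; within the scatter) and a 1.3-fold higher number from compound 2 to compound 3 (0.10 log units; within the scatter). For the measured compounds named here, all three remain within the scatter, although no measured compound carries 3-fluorophenyl.

Compound 1 is the best available guide, as its aromatic group at this place gives a 1.7-fold higher number from compound 1 to compound 3 (0.24 log units; within the scatter) when removed. No step beyond the scatter is therefore expected in this assay, with at most a slight lean towards a lower number. The expected change is a 1.6-fold lower number from compound 3 to compound 4 (0.20 log units; within the scatter), which would still lie within the scatter. For compound 4 the estimated value is 30000 nM, with an expected range from 15000 nM to 55000 nM.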

Compound 4, half-maximal inhibitory concentration: 15600 nM
The estimate for compound 4 lay 1.9-fold (0.28 log units) above the measured number; the measured number falls inside the stated range.
By their numbers in this assay, from the lowest: compounds 4, 1, 2 and 3 (each within the scatter of the next, the first and the last beyond it).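

In this assay, this place now gives its first steps beyond the scatter: a 3.0-fold lower number from compound 3 to compound 4 (0.48 log units; beyond the scatter) and a 2.4-fold lower number from compound 2 to compound 4 (0.38 log units; beyond the scatter), both modest and both with 3-fluorophenyl as the entering group on a saturated chain carbon bound to an oxygen on an aromatic ring. An aromatic group here is not enough on its own to separate a compound from the hydrogen compound, since compound 1 goes against such a pattern with a 1.7-fold higher number from compound 1 to compound 3 (0.24 log units; within the scatter), within the scatter, and 3-fluorophenyl and 4-isopropylphenyl cannot themselves be told apart, with a 1.7-fold lower number from compound 1 to compound 4 (0.24 log units; within the scatter) also within the scatter. The data shown hold no independent information that could explain the lower number of compound 4.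

Whether the fluorine contributes to this step, or the aromatic ring alone accounts for it, would need unsubstituted phenyl at this place, together with a comparison of the same fluorine on other ring positions. Going by these compounds, how this place responds to a group carrying an amine or a carboxylic acid, or to a longer chain between the oxygen and the aromatic ring, also remains open.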